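Removing one fluoro from a difluorophenyl carbamate

This account rests on a few compounds, and the source may have more. Where it says the series, first, only, none or still open, it means among the compounds named here.

Three carbamates built on a shared methylene lactone core have been measured in a functional assay on RAW264.7 cells (Mus musculus) for inhibition, with a stated time of 30 min; a higher number here means a weaker inhibitor, a lower number a stronger inhibitor. Compound 1 `C=C1C(=O)OC[C@H]1CCOC(=O)Nc1ccc(Cl)cc1` gives 390 nM. Compound 2 `C=C1C(=O)OC[C@@H]1CCOC(=O)Nc1ccc(F)cc1F` gives 700 nM, and compound 3 `C=C1C(=O)OC[C@H]1CCOC(=O)Nc1cc(C)cc(C)c1` gives 480 nM. Compound 2 has the highest number of the three, but its gap to compound 3 and its gap to compound 1 both lie within the scatter of repeated measurements, so none of the three can be set apart from the others on these numbers.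

Compound 4 `C=C1C(=O)OC[C@@H]1CCOC(=O)Nc1ccccc1F` has not yet been measured. It differs from compound 2 in one place: hydrogen in place of fluoro on an aromatic carbon. Among the measured compounds shown here, no pair of measured compounds shows the effect of removing a single fluoro from the aromatic ring, so there is no measured step to lean on. Given that the three measured compounds, with quite different aromatic substitution, all fall within the scatter of one another, the expected step from compound 2 to compound 4 is small, a 1.2-fold lower number from compound 2 to compound 4 (0.07 log units; within the scatter), and is not expected to go beyond the scatter in either direction. Compound 4 is therefore estimated at 600 nM, with a range from 300 nM to 1300 nM.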

Compound 4, half-maximal inhibitory concentration: 690 nM
The estimate for compound 4 lay 1.2-fold (0.06 log units) below the measured number; measured number inside the range.
By their numbers in this assay, from the lowest: compounds 1, 3, 4 and 2 (each within the scatter of the next).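

In this assay, among the compounds shown here, putting hydrogen in place of fluoro on the aromatic carbon that is meta to a fluoro group and para to a large group gives a 1.0-fold lower number from compound 2 to compound 4 (0.01 log units; within the scatter), the first step in this set that isolates a change in one place. For the compounds shown here, at this position, then, the fluoro can give way to hydrogen with no effect that can be told from the scatter, something the earlier compounds could not show because they differ from one another in more than one place. No measurement of any property of these compounds bears on this result, so the data offer no account of it.

The compounds shown leave open whether this tolerance extends beyond the exchange of fluoro and hydrogen, for instance to a methoxy group, an amine or a carboxylic acid on the same carbon. They also leave open what happens when hydrogen replaces the fluoro that remains in compound 4, and so whether the carbamate with a plain phenyl ring would stay within the scatter of compound 4.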